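Adding a methoxy group on the amide-bearing ring of compound 1

The source may report more compounds than this note shows. Statements on the series, on what has been measured and on what is new or still open speak of the compounds shown alone.

Measured so far:
compound 1 `COc1ccc(C(=O)c2cc(OC)c(OC)c(OC)c2)cc1NC(=O)/C=C/c1cc(OC)c(OC)c(OC)c1`: 1200 nM
compound 2 `COc1ccc(C(=O)c2cc(OC)c(OC)c(OC)c2)cc1NC(=O)/C=C/c1cccc(OC(F)(F)F)c1`: 6300 nM

In a functional assay on B16 cells (Mus musculus) for cytotoxicity, read by MTT assay, with a stated time of 72 h (a higher number here means a weaker inhibitor, a lower number a stronger inhibitor), compound 1 gives the lowest of the two numbers; compound 2 gives 6300 nM, which is a 5.3-fold higher number from compound 1 to compound 2 (0.72 log units; beyond the scatter). Compound 3 `COc1cc(C(=O)c2cc(OC)c(OC)c(OC)c2)cc(NC(=O)/C=C/c2cc(OC)c(OC)c(OC)c2)c1OC` differs from compound 1 by methoxy in place of hydrogen on an aromatic carbon. Among the measured compounds shown here, no measured step touches this ring, and the only step known, a 5.3-fold higher number from compound 1 to compound 2 (0.72 log units; beyond the scatter), changes the other end of the molecule, so it offers no guide. The expected change for compound 3 in this assay is therefore a 1.3-fold higher number from compound 1 to compound 3 (0.10 log units; within the scatter), within the scatter. Compound 3 is estimated at 1500 nM, between 500 nM and 5000 nM.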

Compound 3, half-maximal inhibitory concentration: 2500 nM
Beside the measured number, compound 3's estimate is 1.7-fold (0.22 log units) below it, and the stated range covers the measured number.
By their numbers in this assay, from the lowest: compound 1; then compound 3; then compound 2.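

In this assay, methoxy in place of hydrogen on this aromatic carbon, ortho to a methoxy group, gives a 2.1-fold higher number from compound 1 to compound 3 (0.32 log units; beyond the scatter) on the amide-bearing ring. Among the compounds shown here, this is the first measured change on that ring, and it shows that the position is not indifferent to the added group, although the step is modest. Nothing available explains this step.

From the compounds shown here alone, whether hydroxyl, fluorine or an amine at this position would behave the same way remains open. So does whether methoxy has a similar effect with the 3-(trifluoromethoxy)phenyl end of compound 2.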